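The source may report more compounds than this note shows. Statements on the series, on what has been measured and on what is new or still open speak of the compounds shown alone.

Measured compounds in an assay on isolated protein for inhibition of sodium channel protein type 9 subunit alpha (Mus musculus), read by patch clamp; a lower number here means a stronger inhibitor, a higher number a weaker inhibitor:
compound 1 `O=C1c2ccccc2CN1C1CCN(CC(O)COc2cccc(C(F)(F)F)c2)CC1`: 790 nM
compound 2 `COc1ccc(OCC(O)CN2CCC(N3Cc4ccccc4C3=O)CC2)cc1`: 1300 nM
compound 3 `O=C1c2ccccc2CN1C1CCN(CC(O)COc2ccc(C(F)(F)F)cc2)CC1`: 100 nM

Compound 3 gives the lowest of the three numbers in this assay. The steps of a 7.9-fold lower number from compound 1 to compound 3 (0.90 log units; beyond the scatter) and a 13-fold lower number from compound 2 to compound 3 (1.11 log units; beyond the scatter) both lie beyond the scatter, so compound 3 stands clearly apart from the other two; the step of a 1.6-fold higher number from compound 1 to compound 2 (0.22 log units; within the scatter) lies within the scatter, so compound 1 and compound 2 cannot be ordered against each other.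

The next compound, compound 4 `COc1cccc(OCC(O)CN2CCC(N3Cc4ccccc4C3=O)CC2)c1`, differs from compound 3 in one place: 3-methoxyphenyl in place of 4-(trifluoromethyl)phenyl on an oxygen on a saturated carbon. Two of the measured steps bear on this change. The step of a 7.9-fold lower number from compound 1 to compound 3 (0.90 log units; beyond the scatter) covers the exchange of 3-(trifluoromethyl)phenyl for 4-(trifluoromethyl)phenyl, and the step of a 13-fold lower number from compound 2 to compound 3 (1.11 log units; beyond the scatter) covers the exchange of methoxy for trifluoromethyl on the aromatic carbon. Compound 4 reverses both of these at once. For the measured compounds named here, both reversed steps point toward a higher number, so a rise in this assay beyond the scatter is expected, with no measured pair to say whether the two parts add fully.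

Compound 4 is therefore estimated at 3000 nM in this assay, with a range of 800 nM to 12000 nM. Compound 4 is thus expected to show the step of a 30-fold higher number from compound 3 to compound 4 (1.48 log units; beyond the scatter).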

Compound 4, half-maximal inhibitory concentration: 910 nM
The estimate for compound 4 lay 3.3-fold (0.52 log units) above the measured number; the range from low to high includes it.
By their numbers in this assay, from the lowest: compound 3; then compounds 1, 4 and 2 (each within the scatter of the next).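

In this assay, 3-methoxyphenyl in place of 4-(trifluoromethyl)phenyl on the oxygen gives a 9.1-fold higher number from compound 3 to compound 4 (0.96 log units; beyond the scatter), so the gap between compound 3 and the methoxy compounds is not confined to compound 2. The other two steps do not separate their compounds: 3-methoxyphenyl in place of 4-methoxyphenyl gives a 1.4-fold lower number from compound 2 to compound 4 (0.15 log units; within the scatter), and 3-methoxyphenyl in place of 3-(trifluoromethyl)phenyl gives a 1.2-fold higher number from compound 1 to compound 4 (0.06 log units; within the scatter), leaving compounds 1, 2 and 4 unordered, with only the 4-(trifluoromethyl)phenyl of compound 3 standing apart. Trifluoromethyl in place of methoxy on the aromatic carbon therefore does not give one constant step on this aryl group, and its size depends on which of the two aryl arrangements carries it: the same change on two cores in this assay, a 13-fold lower number (1.11 log units; beyond the scatter) from compound 2 to compound 3 and a 1.2-fold lower number (0.06 log units; within the scatter) from compound 4 to compound 1, 11-fold (1.05 log units) apart, beyond the scatter of two such steps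

The compounds shown leave open whether the low number of compound 3 is particular to trifluoromethyl, which a 4-chlorophenyl or 4-cyanophenyl group on the same oxygen would help to settle. They also leave open what an amine in place of the hydroxyl on the chain would do in this assay.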